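The compounds below may be only part of what the source reports. "The series", "measured", "known", "first", "only" and "open" are said of these compounds alone.

For the measured compounds named here, in a functional assay on HepG2 cells (Homo sapiens) for antiproliferative activity, read by MTT assay, with a stated time of 48 h (a higher number here means a weaker inhibitor, a lower number a stronger inhibitor), compound 1 `O=C(/C=C/c1ccc(/C=C/C(=O)c2cccc(Cl)c2)o1)NO` gives 54500 nM, the higher of the two numbers so far, and compound 2 `O=C(/C=C/c1ccc(/C=C/C(=O)c2ccc(Cl)cc2)o1)NO` gives 6740 nM. Compound 3 `O=C(/C=C/c1ccc(/C=C/C(=O)c2cc(Cl)ccc2Cl)o1)NO` keeps the core of compound 1 and differs by chloro in place of hydrogen on an aromatic carbon, ortho to a large group and para to a chloro group. Going by the values given here, the only measured step, an 8.1-fold lower number from compound 1 to compound 2 (0.91 log units; beyond the scatter), relocates a chlorine rather than adding one, so it is an indirect guide. On that slim evidence, a moderate move toward a lower number is expected, a 3.0-fold lower number from compound 1 to compound 3 (0.48 log units; beyond the scatter). For compound 3 the estimated value is 18000 nM, with an expected range from 5000 nM to 60000 nM.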

Compound 3, half-maximal inhibitory concentration: 48300 nM
Compound 3: the middle estimate sits 2.7-fold (0.43 log units) below what was measured; measured number inside the range.
By their numbers in this assay, from the lowest: compound 2; then compounds 3 and 1 (each within the scatter of the next).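

In this assay chloro in place of hydrogen on this aromatic carbon, ortho to a large group and para to a chloro group, gives a 1.1-fold lower number from compound 1 to compound 3 (0.05 log units; within the scatter) and so leaves compound 1 and compound 3 indistinguishable. The earlier compounds shown here showed only a chlorine relocated, whereas this pair shows that a second chlorine at this place is carried with no change beyond the scatter. Nothing measured here explains this result. On these data alone, whether an amine or a methoxy group on the same carbon would match chloro remains open.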